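This account rests on a few compounds, and the source may have more. Where it says the series, first, only, none or still open, it means among the compounds named here.

Series so far, all in a functional assay on HeLa cells (Homo sapiens) for antiproliferative activity, read by MTT assay, with a stated time of 72 h (on this read-out higher numbers stand for weaker inhibition and lower numbers for stronger inhibition), as the read-out:
compound 1 `Nc1nc(N)c2cc(CSC(=S)N3CCN(c4ccc(O)cc4)CC3)ccc2n1` gives 5180 nM
compound 2 `Cc1ccccc1N1CCN(C(=S)SCc2ccc3nc(N)nc(N)c3c2)CC1` gives "not determined" (no result reported)
compound 3 `Cc1ccc(N2CCN(C(=S)SCc3ccc4nc(N)nc(N)c4c3)CC2)c(C)c1` gives 3190 nM

Compound 2 has no single number in this assay and so offers no value to step from. Among the measured compounds shown here, compound 4 `Nc1nc(N)c2cc(CSC(=S)N3CCN(c4ccccc4F)CC3)ccc2n1` differs from compound 2 by fluoro in place of methyl on an aromatic carbon as its one change, fluoro in place of methyl on an aromatic carbon, ortho to a large group. For the measured compounds named here, the only measured step, a 1.6-fold lower number from compound 1 to compound 3 (0.21 log units; within the scatter), lies within the scatter and is a different change. No step size or direction can therefore be expected from compound 2. The expectation rests on compound 1 at 5180 nM and compound 3 at 3190 nM as the level of the series. Compound 4 is expected at about 4000 nM as an estimate, with an expected range from 1500 nM to 11000 nM as its limits of estimation.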

Compound 4, half-maximal inhibitory concentration: 6660 nM
The estimate for compound 4 lay 1.7-fold (0.22 log units) below the measured number, within the range that was stated.
By their numbers in this assay, from the lowest: compounds 3, 1 and 4 (each within the scatter of the next, the first and the last beyond it).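

In this assay, among the compounds shown here, 2-fluorophenyl gives the first step beyond the scatter, against 2,4-dimethylphenyl (a 2.1-fold higher number from compound 3 to compound 4 (0.32 log units; beyond the scatter)), though only a modest one, while against 4-hydroxyphenyl it shows no separation (a 1.3-fold higher number from compound 1 to compound 4 (0.11 log units; within the scatter)). The step from 2-methylphenyl to 2-fluorophenyl cannot be read, since compound 2 has no single number, so the swap of methyl for fluoro on this aromatic carbon stays without a size or direction. No evidence at hand bears on the reason for these differences.

Open, on these data alone, is how a chloro, methoxy or amine group would read on the same aromatic carbon, ortho to a large group.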